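A few compounds are considered here, and "the series" means these few. Any claim that something is new, unique, unknown or untested is made for them only; others in the source may bear on it.

Among the compounds with values here, in a functional assay on muscle tissue for agonist activity at histamine H2 receptor (Cavia porcellus) (a higher number here means a more potent compound, by a factor of ten per unit of this negative logarithm, a lower number a less potent compound), compound 2 `N=C(NCCCc1c[nH]cn1)NCCC(c1ccc(Br)cc1)c1ccccn1` gives 6.97, the lowest of the three values measured so far. Compound 1 `Cc1ccc(C(CC/N=C(\N)NCCCc2c[nH]cn2)c2ccccn2)cc1` gives 7.15, which lies within the scatter of compound 2, while compound 3 `N=C(NCCCc1c[nH]cn1)NCCC(c1cccc(F)c1)c1ccccn1` gives 7.79, beyond it. Compound 4 `N=C(NCCCc1c[nH]cn1)NCCC(c1ccc(Cl)c(Cl)c1)c1ccccn1` differs from compound 2 by 3,4-dichlorophenyl in place of 4-bromophenyl on a saturated chain carbon bound to an aromatic carbon and a saturated chain carbon. Within the data shown here, only one measured step bears on this change, the one where a 3-fluorophenyl took the place of the same 4-bromophenyl, and it gave a number 0.82 log units higher from compound 2 to compound 3 (beyond the scatter). Because the change to compound 4 is related but not identical to that step a number 0.82 log units higher from compound 2 to compound 3 (beyond the scatter), a smaller rise is expected, a number 0.43 log units higher from compound 2 to compound 4 (beyond the scatter). Compound 4 is therefore estimated at 7.4, with a range from 6.9 to 7.9.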

Compound 4, negative logarithm of the half-maximal effective concentration: 7.54
Beside the measured number, compound 4's estimate is 0.14 log units below it; measured number inside the range.
By their numbers in this assay, from the lowest: compounds 2 and 1 (each within the scatter of the next); then compounds 4 and 3 (each within the scatter of the next).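

Replacing the 4-bromophenyl now pays a second time: 3,4-dichlorophenyl gives a number 0.57 log units higher from compound 2 to compound 4 (beyond the scatter), so the rise seen with compound 3 does not depend on fluorine. The two replacements cannot be told apart, with a number 0.25 log units lower from compound 3 to compound 4 (within the scatter), so quite different halogen patterns on this phenyl ring can end up at a similar level. Nothing available explains why either ring outperforms the 4-bromophenyl. Still open, as far as these compounds go, is whether a phenyl ring carrying a methoxy group or a nitrile would reach the same level, or whether the gain needs a halogen at all.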